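From a Tetrahydronaphthalenyl Amide to a Methoxyphenylethenyl Amide

This account rests on a few compounds, and the source may have more. Where it says the series, first, only, none or still open, it means among the compounds named here.

Compound 1 `CN1[C@@H]2c3[nH]c4ccccc4c3C[C@H]1[C@H](C#N)N1[C@@H](CNC(=O)c3cccc4c3CCCC4)c3[nH]c4ccccc4c3C[C@@H]21`: 3540 nM
Compound 2 `CN1[C@@H]2c3[nH]c4ccccc4c3C[C@H]1[C@H](C#N)N1[C@@H](CNC(=O)c3cc4ccccc4o3)c3[nH]c4ccccc4c3C[C@@H]21`: 210 nM
Compound 3 `CN1[C@@H]2c3[nH]c4ccccc4c3C[C@H]1[C@H](C#N)N1[C@@H](CNC(=O)/C=C/c3ccccc3)c3[nH]c4ccccc4c3C[C@@H]21`: 4300 nM

These three amides share one core and differ only in the group on the carbonyl carbon, tested in a functional assay on BGC-823 cells (Homo sapiens) for cytotoxicity, read by MTT assay, with a stated time of 72 h; a higher number here means a weaker inhibitor, a lower number a stronger inhibitor. Compound 1 stands second highest of the three numbers; its nearest neighbour is compound 3, with a 1.2-fold higher number from compound 1 to compound 3 (0.08 log units; within the scatter), while compound 2 sits far off, with a 17-fold lower number from compound 1 to compound 2 (1.23 log units; beyond the scatter). Compound 4 `COc1ccc(/C=C/C(=O)NC[C@H]2c3[nH]c4ccccc4c3C[C@H]3[C@H]4c5[nH]c6ccccc6c5C[C@@H]([C@H](C#N)N23)N4C)cc1` is not yet measured. It differs from compound 1 in that (2-(4-methoxyphenyl)ethenyl in place of 1,2,3,4-tetrahydronaphthalen-5-yl on a carbonyl carbon), so that the whole change reads (1,2,3,4-tetrahydronaphthalen-5-yl)carbonyl to (2-(4-methoxyphenyl)ethenyl)carbonyl. The step of a 1.2-fold higher number from compound 1 to compound 3 (0.08 log units; within the scatter) bears most directly, being a move to the unsubstituted 2-phenylethenyl amide; nothing here tells what the added methoxy group does. Compound 4 is therefore expected to lie close to compound 1, with a 1.1-fold higher number from compound 1 to compound 4 (0.05 log units; within the scatter), at an estimated 4000 nM within 1500 nM to 11000 nM.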

Compound 4, half-maximal inhibitory concentration: 5450 nM
For compound 4 the middle estimate is 1.4-fold (0.13 log units) below the measured one; low and high end bracket the measured number.
By their numbers in this assay, from the lowest: compound 2; then compounds 1, 3 and 4 (each within the scatter of the next).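

In this assay, methoxy in place of hydrogen on an aromatic carbon of the 2-phenylethenyl amide gives a step within the scatter (a 1.3-fold higher number from compound 3 to compound 4 (0.10 log units; within the scatter)). The 2-(4-methoxyphenyl)ethenyl amide likewise cannot be told apart from the tetrahydronaphthalenyl amide (a 1.5-fold higher number from compound 1 to compound 4 (0.19 log units; within the scatter)), yet remains far from the 1-benzofuran-2-yl amide (a 26-fold higher number from compound 2 to compound 4 (1.41 log units; beyond the scatter)). No evidence is available to explain these steps.

The compounds shown leave open whether an amine or a carboxylic acid in place of the methoxy would shift the number. They also leave open whether methoxy on the 1-benzofuran-2-yl group would keep that amide apart.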